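Permeability notes on three measured analogues and one pending

The compounds below may be only part of what the source reports. "The series", "measured", "known", "first", "only" and "open" are said of these compounds alone.

compound 1 `FC(F)(F)c1ccc(-c2ccc3c(NCCCNCc4ccco4)ccnc3c2)cc1` in an ADME assay for permeability, using PAMPA, with a stated time of 30 min, at pH 7.4; a lower number here means that the compound crosses the layer more slowly, a higher number that the compound crosses the layer faster: 237 10^-6 cm/s
compound 2 `c1ccc(Cc2ccc3c(NCCCNCc4ccco4)ccnc3c2)cc1` in this assay: 23 10^-6 cm/s
compound 3 `COc1cccc(CNCCCNc2ccnc3cc(-c4ccc(C(F)(F)F)cc4)ccc23)c1O` in this assay: 237 10^-6 cm/s

Compound 2 stands apart from the other two: a 10-fold lower number from compound 1 to compound 2 (1.01 log units; beyond the scatter), the change being (benzyl in place of 4-(trifluoromethyl)phenyl on an aromatic carbon). Compound 3 differs from compound 1 by 2-hydroxy-3-methoxyphenyl in place of furan-2-yl on a saturated chain carbon bound to an amine nitrogen, and no change at the digits printed from compound 1 to compound 3 (within the scatter); the two stand level in this assay.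

Compound 4 `COc1cccc(CNCCCNc2ccnc3cc(Cc4ccccc4)ccc23)c1O` is not yet measured. It differs from compound 3 by benzyl in place of 4-(trifluoromethyl)phenyl on an aromatic carbon, the same change as from compound 1 to compound 2, at the same place on the shared core. The expected step is a 9.5-fold lower number from compound 3 to compound 4 (0.98 log units; beyond the scatter), resting on a 10-fold lower number from compound 1 to compound 2 (1.01 log units; beyond the scatter) and on the level standing of compound 3 with compound 1. In this assay compound 4 is expected near 25 10^-6 cm/s, with a likely range from 10 10^-6 cm/s to 60 10^-6 cm/s.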

Compound 4, apparent permeability: 23 10^-6 cm/s
Compound 4: the middle estimate sits 1.1-fold (0.04 log units) above what was measured, and the stated range covers the measured number.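

Benzyl in place of 4-(trifluoromethyl)phenyl gives a 10-fold lower number from compound 3 to compound 4 (1.01 log units; beyond the scatter) in this assay, matching the earlier step on the other core: the same change on two cores in this assay, a 10-fold lower number (1.01 log units; beyond the scatter) from compound 1 to compound 2 and a 10-fold lower number (1.01 log units; beyond the scatter) from compound 3 to compound 4, 1.0-fold (0.00 log units) apart, within the scatter of two such steps. 2-Hydroxy-3-methoxyphenyl in place of furan-2-yl gives no change at the digits printed from compound 2 to compound 4 (within the scatter), and this too matches the earlier step: the same change on two cores in this assay, no change at the digits printed (within the scatter) from compound 1 to compound 3 and no change at the digits printed (within the scatter) from compound 2 to compound 4, 1.0-fold (0.00 log units) apart, within the scatter of two such steps. Among the compounds shown here, the two changes therefore carried over cleanly within these four compounds, but that rests on only two cores in one assay and does not show why the number moves or that the step would hold on any further core.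

Open, going by these compounds, is whether the step survives with a carboxylic acid or an amine on the benzyl ring. On these data alone, a longer chain linking the two amine nitrogens is equally open.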